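Taking a side group off a compound at the limit

The source may hold more compounds than are shown below. What is called first, only, known or untested is meant among the compounds shown, and "the series" means these compounds.

Results in a functional assay on Raji cells (Homo sapiens) for cytotoxicity, with a stated time of 72 h (a lower number here means that less compound is needed, a higher number that more compound is needed for the effect), for the measured compounds
Compound 1 `C=C[C@@](C)(/C=C/c1ccc(O)c(C=O)c1)CCC=C(C)C` gives > 26000 nM as a limit
Compound 2 `C=C[C@@](C)(/C=C/c1ccc(O)c(/C=C/C(=O)OCC)c1)CCC=C(C)C` gives > 26000 nM as a limit
Compound 3 `CCOC(=O)/C=C/c1cc(/C=C/[C@](C)(/C=C/c2ccc(OC)cc2)CCC=C(C)C)ccc1O` gives > 26000 nM as a limit

Compound 3 stands at > 26000 nM in this assay and this is a limit, not a number. The data so far show the limit of > 26000 nM in this assay, at which 3 of the 3 values shown sit, and nothing more. Compound 4 `COc1ccc(/C=C/[C@@](C)(/C=C/c2ccc(O)cc2)CCC=C(C)C)cc1` differs from compound 3 by one change: hydrogen in place of 2-(ethoxycarbonyl)ethenyl on an aromatic carbon. For the measured compounds named here, two measured steps bear on it, a step that the two limits leave unreadable from compound 1 to compound 2 on an aromatic carbon and a step that the two limits leave unreadable from compound 2 to compound 3 on a saturated chain carbon. Neither offers a size or a direction to carry over, so no step beyond the scatter is expected, and the expected step is a number no higher from compound 3 to compound 4 (the limit leaves the size open) in this estimate. For compound 4 the estimate is 26000 nM with an expected range from 10000 nM to 50000 nM in this assay's terms.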

Compound 4, half-maximal effective concentration: > 26000 nM
Compound 4: a limit, no number; the forecaster's own chance of this, stated with the estimate: 75%; the middle value lies on the limit itself.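

For the compounds shown here, no step from compound 3 to compound 4 can be read, because both results are limits and not numbers: the limit of > 26000 nM in this assay, at which 4 of the 4 values shown sit. The compounds shown leave open which change, if any, would give a real number in this assay.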